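From 5-methylthiophen-2-yl to thiophen-2-yl in compound 3

The source may hold more compounds than are shown below. What is called first, only, known or untested is meant among the compounds shown, and "the series" means these compounds.

In a functional assay on HeLa cells (Homo sapiens) for cytotoxicity, read by MTT assay, with stated times of 3 h and 24 h (on this read-out lower numbers stand for stronger inhibition and higher numbers for weaker inhibition), the series has two measured members. Compound 1 `COc1ccc(C2=[N+]3C(=Nc4c(-c5ccccc5)c5c(n4[B-]3(F)F)-c3ccc(OC)cc3CC5)C(c3ccccc3)=C2I)cc1` gives 81 nM, and compound 2 `COc1ccc2c(c1)CCc1c(-c3ccccc3)c3n(c1-2)[B-](F)(F)[N+]1=C(c2ccc(C)s2)C(I)=C(c2ccccc2)C1=N3` gives 12300 nM, the higher of the two numbers. Compound 3 `COc1ccc2c(c1)CCc1c(-c3ccccc3)c3n(c1-2)[B-](F)(F)[N+]1=C(c2cccs2)C(I)=C(c2ccccc2)C1=N3` keeps the core of compound 2 and differs by hydrogen in place of methyl on an aromatic carbon, so that 5-methylthiophen-2-yl becomes thiophen-2-yl. Among the compounds with values here, no measured step covers this exact change. The nearest evidence is a 150-fold higher number from compound 1 to compound 2 (2.18 log units; beyond the scatter), a large step with 5-methylthiophen-2-yl in place of 4-methoxyphenyl. The present change is much smaller, so only a modest step towards a lower number is expected in this assay, and its direction is uncertain. The expected change is a 2.1-fold lower number from compound 2 to compound 3 (0.31 log units; beyond the scatter). For compound 3 the estimated value is 6000 nM, with an expected range of 1000 nM to 25000 nM.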

Compound 3, half-maximal inhibitory concentration: 460 nM
The estimate for compound 3 lay 13-fold (1.12 log units) above the measured number, and the stated range ends above it.
By their numbers in this assay, from the lowest: compound 1; then compound 3; then compound 2.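

In this assay, hydrogen in place of methyl next to the ring sulfur, turning 5-methylthiophen-2-yl into thiophen-2-yl, gives a 27-fold lower number from compound 2 to compound 3 (1.43 log units; beyond the scatter) and shows that this single methyl alone accounts for a large step. The larger part of the earlier gap between 4-methoxyphenyl and 5-methylthiophen-2-yl therefore goes with the methyl, since thiophen-2-yl in place of 4-methoxyphenyl leaves a 5.7-fold higher number from compound 1 to compound 3 (0.75 log units; beyond the scatter) as a modest step that is still beyond the scatter. Nothing available here accounts for the size of the methyl step.

Open, as far as these compounds go, is whether any group at this ring carbon raises the number as methyl does, or only methyl; a chlorine, an ethyl or an aminomethyl there would test this. Also open, from the compounds shown here alone, is whether a furan-2-yl would read like thiophen-2-yl.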